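Methoxyphenyl Amide on the Benzyloxy Core: Likely Still Inactive

This account rests on a few compounds, and the source may have more. Where it says the series, first, only, none or still open, it means among the compounds named here.

Compound 1, `COCOc1cc(/C=C/C(=O)OCC(=O)Nc2ccc(Cl)cc2)ccc1OCc1ccccc1`, in a functional assay on ECa-109 cells (Homo sapiens) for cytotoxicity, read by MTT assay, with a stated time of 72 h (on this read-out lower numbers stand for stronger inhibition and higher numbers for weaker inhibition), gives > 200000 nM, a limit of the assay.
Compound 2, `COc1ccc(/C=C/C(=O)OCC(=O)Nc2ccc(Cl)cc2)cc1OC`, in this assay gives 81900 nM.
Compound 3, `COCOc1cc(/C=C/C(=O)OCC(=O)Nc2nccs2)ccc1OCc1ccccc1`, in this assay gives > 200000 nM, a limit of the assay.

Compound 3 therefore stands at the limit of the assay, where (the limit of > 200000 nM in this assay, at which 2 of the 3 values shown sit). Within the data shown here, the one measured step that touches its amide substituent is a step that the two limits leave unreadable from compound 1 to compound 3, and its size cannot be read because both ends are limits. Among the measured compounds shown here, compound 2, which carries the 4-chlorophenyl amide on a different core, is the only compound with a numerical value.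

The step to compound 4, `COCOc1cc(/C=C/C(=O)OCC(=O)Nc2ccc(OC)cc2)ccc1OCc1ccccc1`, is 4-methoxyphenyl in place of 1,3-thiazol-2-yl on an amide-type nitrogen. For the measured compounds named here, no measured step shows what a 4-methoxyphenyl amide does on this core, and the one step at the same position is unreadable. Since compound 1 and compound 3 both sit at the limit, the expectation is that exchanging the amide aryl group again leaves compound 4 at or near that limit, with an expected step of a number no higher from compound 3 to compound 4 (the limit leaves the size open), essentially none beyond the scatter. Compound 4 is thus estimated at 200000 nM, with a range from 100000 nM to 400000 nM.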

Compound 4, half-maximal inhibitory concentration: > 200000 nM
Compound 4: a limit, no number; the forecaster's own chance of this, stated with the estimate: 70%; the middle value lies on the limit itself.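

In this assay compound 4 gives > 200000 nM as a limit and not a number. The steps to compound 4 from compound 3 and from compound 1 therefore cannot be read: the limit of > 200000 nM in this assay, at which 3 of the 4 values shown sit. The compounds shown leave open whether any amide substituent on the shared core of compound 1, compound 3 and compound 4 changes the read-out.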